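This account rests on a few compounds, and the source may have more. Where it says the series, first, only, none or still open, it means among the compounds named here.

Compound 1, with the structure `CCOC(=O)c1csc2nc(CN3CCN(Cc4ccccc4)CC3)c(-c3ccc(C)cc3)n12`, and compound 2, with the structure `CCOC(=O)c1csc2nc(CN3CCN(Cc4ccccc4)CC3)c(-c3ccc(OC)cc3)n12`, share one core, and in a functional assay on HepG2 cells (Homo sapiens) for antiproliferative activity, read by MTT assay, with a stated time of 72 h (on this read-out higher numbers stand for weaker inhibition and lower numbers for stronger inhibition), compound 1 gives 88200 nM while compound 2 gives 26400 nM. The change between them, (methoxy in place of methyl on an aromatic carbon), produced a 3.3-fold lower number from compound 1 to compound 2 (0.52 log units; beyond the scatter). Compound 3, with the structure `Cc1ccc(-c2c(CN3CCCCC3)nc3scc(C(=O)O)n23)cc1`, rests on a different core, and the difference between the two cores is not broken down here; in this assay compound 3 gives 10800 nM, the lowest of the three numbers, with both of its steps to the others beyond the scatter. Compound 4, with the structure `COc1ccc(-c2c(CN3CCCCC3)nc3scc(C(=O)O)n23)cc1`, carries the same change on the core of compound 3: methoxy in place of methyl on an aromatic carbon. The place of the change reads the same in both pairs, so it is taken as the same change. Going by the values given here, for compound 4 the step of a 2.4-fold lower number from compound 3 to compound 4 (0.38 log units; beyond the scatter) is expected in this assay, a little smaller than the earlier one, because the only precedent is compound 1 to compound 2 with a 3.3-fold lower number from compound 1 to compound 2 (0.52 log units; beyond the scatter) and a single pair on another core is thin ground. Compound 4 is therefore estimated at 4500 nM, between 1500 nM and 13000 nM.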

Compound 4, half-maximal inhibitory concentration: 75100 nM
Estimate against measurement, compound 4: 17-fold (1.22 log units) below, outside the stated range (above it).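

In this assay, the change from 4-methylphenyl to 4-methoxyphenyl gave a 7.0-fold higher number from compound 3 to compound 4 (0.84 log units; beyond the scatter), the opposite direction to the one seen on the core of compound 1. Set side by side, the two steps differ in direction and in size: the same change on two cores in this assay, a 3.3-fold lower number (0.52 log units; beyond the scatter) from compound 1 to compound 2 and a 7.0-fold higher number (0.84 log units; beyond the scatter) from compound 3 to compound 4, 23-fold (1.37 log units) apart, beyond the scatter of two such steps. This shows that, among these four compounds, the result of this change on one core did not predict its result on the other, but it does not show what reverses the step, and with one pair on each core it cannot show how general either direction is.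

The compounds shown leave open whether the reversal goes with the carboxylic acid or with the piperidine, since the two cores differ in more than one place and no pair here separates the acid from the ethyl ester or the piperidine from the benzylpiperazine. Also open, as far as these compounds go, is whether a hydroxy group or a chlorine atom on the same aromatic carbon would follow the step seen on either core.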